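Compound 3 to compound 4: one fluoro leaves

This account rests on a few compounds, and the source may have more. Where it says the series, first, only, none or still open, it means among the compounds named here.

Measured in a functional assay on A549 cells (Homo sapiens) for antiproliferative activity, read by MTT assay, with a stated time of 72 h; on this read-out lower numbers stand for stronger inhibition and higher numbers for weaker inhibition:
Compound 1 `CC(C)NC(=N)NC(=N)Nc1ccc(C(F)(F)F)cc1`: 3600 nM
Compound 2 `CC(C)CNC(=N)NC(=N)Nc1ccc(F)c(F)c1`: 2400 nM
Compound 3 `CC(C)NC(=N)NC(=N)Nc1ccc(F)c(F)c1`: 5200 nM

Compound 3 lies within the usual scatter of compound 1. For the measured compounds named here, the one measured step is a 2.2-fold higher number from compound 2 to compound 3 (0.34 log units; beyond the scatter), with isopropyl in place of isobutyl on an amine nitrogen.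

Compound 4 `CC(C)NC(=N)NC(=N)Nc1ccc(F)cc1` has hydrogen in place of fluoro on an aromatic carbon of compound 3: hydrogen in place of fluoro on an aromatic carbon. The measured step changes a different place, so it tests this change only indirectly, showing just that one small swap can move the number modestly. A modest rise in this assay is therefore expected, although the data do not settle the direction. The estimated change is a 1.5-fold higher number from compound 3 to compound 4 (0.19 log units; within the scatter). Compound 4 is estimated at 8000 nM, with an expected range of 3500 nM to 20000 nM.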

Compound 4, half-maximal inhibitory concentration: 7500 nM
Beside the measured number, compound 4's estimate is 1.1-fold (0.03 log units) above it, and the stated range covers the measured number.
By their numbers in this assay, from the lowest: compounds 2, 1, 3 and 4 (each within the scatter of the next, the first and the last beyond it).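

In this assay, removing this one fluoro gives a 1.4-fold higher number from compound 3 to compound 4 (0.16 log units; within the scatter), so the loss of a fluoro at this place on the ring cannot be told apart from repeat scatter. Exchanging a whole trifluoromethyl group for fluoro gives a 2.1-fold higher number from compound 1 to compound 4 (0.32 log units; beyond the scatter), a modest step that does clear the scatter. Nothing measured here explains either step.

Still open, from the compounds shown here alone, is how a chloro, a methoxy or an amine would behave on this aromatic carbon. Going by these compounds, it is also open whether an isobutyl on the amine nitrogen would keep its modest step when the ring carries a single fluoro.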